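The source may hold more compounds than are shown below. What is called first, only, known or untested is meant among the compounds shown, and "the series" means these compounds.

Measured in a functional assay on MCF7 cells (Homo sapiens) for inhibition, read by sulforhodamine B assay, with a stated time of 72 h; on this read-out lower numbers stand for stronger inhibition of growth and higher numbers for weaker inhibition of growth:
- compound 1 `CN1CCN(C(=O)/C=C/c2ccncc2-c2ccc3ccccc3c2)CC1`: > 10000 nM (a limit of the assay)
- compound 2 `O=C(O)/C=C/c1ccncc1-c1ccc2ccccc2c1`: > 10000 nM (a limit of the assay)
- compound 3 `COC(=O)/C=C/c1ccncc1-c1ccc2ccccc2c1`: 8170 nM

Going by the values given here, compound 3 is the only compound here with a number, 8170 nM. Compound 1 and compound 2 both stand at the limit of > 10000 nM in this assay, at which 2 of the 3 values shown sit.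

Compound 4 `O=C(/C=C/c1ccncc1-c1ccc2ccccc2c1)N1CCOCC1` departs from compound 3 on the carbonyl carbon: morpholin-4-yl in place of methoxy on a carbonyl carbon. The methoxycarbonyl thus becomes (morpholin-4-yl)carbonyl.

The closest measured step is an at least 1.2-fold lower number from compound 1 to compound 3 (0.08 log units; that floor lies within the scatter), which places methoxy where compound 1 carries 4-methylpiperazin-1-yl on the same carbonyl carbon. Compound 4 reverses that kind of exchange, with morpholin-4-yl as the incoming group. The step of an at least 1.2-fold lower number from compound 2 to compound 3 (0.08 log units; that floor lies within the scatter) bears on it less directly, since it only adds methyl to the oxygen of the acid. Both steps give only a floor, so neither fixes a real size.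

In this assay, no step beyond the scatter is expected, with any drift towards weaker inhibition of growth. The estimated change is a 1.2-fold higher number from compound 3 to compound 4 (0.09 log units; within the scatter). Compound 4 may well be reported only as a limit, as compound 1 was. For compound 4 the expected value is 10000 nM, within an estimated range of 5000 nM to 20000 nM.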

Compound 4, concentration for 50% growth inhibition: > 10000 nM
Compound 4 was reported as a limit; the forecaster's own chance of this, stated with the estimate: 60%; the middle value lies on the limit itself.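

In this assay, morpholin-4-yl in place of methoxy on the carbonyl carbon gives an at least 1.2-fold higher number from compound 3 to compound 4 (0.08 log units; that floor lies within the scatter), so this exchange has only a floor and no fixed size. The steps to compound 4 from compound 1 and from compound 2 cannot be read, as both ends of each are limits. On this carbonyl carbon only the methoxy of compound 3 gives a number, while compound 4 is reported as a limit and joins compound 1 and compound 2 there: the limit of > 10000 nM in this assay, at which 3 of the 4 values shown sit.

Still open, as far as these compounds go, is how far compound 1, compound 2 and compound 4 actually lie from compound 3, which has a measured value of 8170 nM, and whether any group on this carbonyl carbon can move the number beyond the scatter of the assay. An ethoxy group or a simple unsubstituted amino group in the same place would show whether the measurable value stays with the ester or whether a small amide can also leave the limit.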